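A few compounds are considered here, and "the series" means these few. Any claim that something is new, unique, unknown or untested is made for them only; others in the source may bear on it.

Measured in a functional assay on the whole organism (aorta) with Rattus norvegicus as the target; on this read-out lower numbers stand for smaller maximal responses and higher numbers for larger maximal responses:
compound 1 `CNC(=O)C1=CC(C)(CF)Oc2ccc([N+](=O)[O-])cc21` — 66%
compound 2 `CNC(=O)C1=CC(C)(C(F)(F)F)Oc2ccc([N+](=O)[O-])cc21` — 61.7%
compound 3 `CC1(CF)C=C(C(=O)NCCC#N)c2cc([N+](=O)[O-])ccc2O1` — 71%

Compound 2 differs from compound 1 by trifluoromethyl in place of fluoromethyl on a saturated ring carbon, and the step is a number 4.3 percentage points lower from compound 1 to compound 2 (within the scatter). Compound 3 differs from compound 1 by cyanomethyl in place of hydrogen on a saturated chain carbon bound to an amide-type nitrogen, and the step is a number 5 percentage points higher from compound 1 to compound 3 (within the scatter). Compound 2 and compound 3 are not joined by a counted step; their values lie within the scatter of each other, so no order between them is claimed.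

Compound 4 `CC1(C(F)(F)F)C=C(C(=O)NCCC#N)c2cc([N+](=O)[O-])ccc2O1` is not yet measured in this assay. It differs from compound 3 by trifluoromethyl in place of fluoromethyl on a saturated ring carbon. Going by the values given here, this is the same kind of change as the one from compound 1 to compound 2, but not the same: in compound 1 the ring atom two ring bonds away bears a methylcarbamoyl group (4 heavy atoms), in compound 3 it bears a (2-cyanoethyl)carbamoyl group (7 heavy atoms). Among the compounds with values here, with only one earlier instance of this change, the step for compound 4 is expected to be a number 4 percentage points lower from compound 3 to compound 4 (within the scatter), resting on the step seen from compound 1 to compound 2, a number 4.3 percentage points lower from compound 1 to compound 2 (within the scatter), which was within the scatter. Compound 4 is thus estimated at 67% in this assay, with a range from 57% to 77%.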

Compound 4, intrinsic activity: the largest response reached, in percent of the reference agonist's: 70.6%
The estimate for compound 4 lay 3.6 percentage points below the measured number; measured number inside the range.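

In this assay, trifluoromethyl in place of fluoromethyl on the saturated ring carbon gives a number 0.4 percentage points lower from compound 3 to compound 4 (within the scatter), in line with its earlier instance: the same change on two cores in this assay, a number 4.3 percentage points lower (within the scatter) from compound 1 to compound 2 and a number 0.4 percentage points lower (within the scatter) from compound 3 to compound 4, 3.9 percentage points apart, within the scatter of two such steps
Cyanomethyl in place of hydrogen on the chain carbon bound to the amide nitrogen gives a number 8.9 percentage points higher from compound 2 to compound 4 (within the scatter), and this change also reads alike on both cores: the same change on two cores in this assay, a number 5 percentage points higher (within the scatter) from compound 1 to compound 3 and a number 8.9 percentage points higher (within the scatter) from compound 2 to compound 4, 3.9 percentage points apart, within the scatter of two such steps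
Each change therefore carries from one core to the other without a detectable difference between its two steps, but since every step lies within the scatter, neither change has a demonstrated effect on the maximal response and no additive behaviour can be claimed.

The four compounds cover only fluoromethyl and trifluoromethyl on the ring carbon, and only methylcarbamoyl and (2-cyanoethyl)carbamoyl on the other ring atom. Open, on these data alone, is whether a difluoromethyl or ethyl group on the ring carbon, or a longer chain or one ending in an amine or a carboxylic acid on the amide nitrogen, would move the read-out beyond the scatter.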